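The source may report more compounds than this note shows. Statements on the series, on what has been measured and on what is new or still open speak of the compounds shown alone.

Measured compounds:
- compound 1, `Nc1scc(CN2CCN(c3cc(Cl)cc(Cl)c3)CC2)c1C(=O)c1ccc(Cl)cc1`: 1%
- compound 2, `Nc1scc(CN2CCN(c3cccc(C(F)(F)F)c3)CC2)c1C(=O)c1ccc(Cl)cc1`: 0%
- compound 3, `Nc1scc(CN2CCN(c3ccccc3C(F)(F)F)CC2)c1C(=O)c1ccc(Cl)cc1`: 0%

In an assay on CHO cells for displacement of a labelled ligand from adenosine receptor A1 (Homo sapiens), read by scintillation counting, with a stated time of 120 min, tested at 10 uM (a higher number here means more inhibition at the concentration tested (going by the name of the read-out), a lower number less inhibition), compound 3 gives 0%, level with compound 2 at the digits shown and together with it the lowest of the three numbers; its furthest neighbour is compound 1, and the step of a number 1 percentage points lower from compound 1 to compound 3 (within the scatter) lies within the scatter, as does no change at the digits printed from compound 2 to compound 3 (within the scatter). All three values sit at the floor of the read-out.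

Compound 4, `Nc1scc(CN2CCN(c3ccc(Cl)c(C(F)(F)F)c3)CC2)c1C(=O)c1ccc(Cl)cc1`, is not yet measured. Its difference from compound 3 is 4-chloro-3-(trifluoromethyl)phenyl in place of 2-(trifluoromethyl)phenyl on an amine nitrogen in a ring. Among the measured compounds shown here, the steps that bear on this are the three variations of the aryl group on the ring nitrogen, a number 1 percentage points lower from compound 1 to compound 2 (within the scatter), a number 1 percentage points lower from compound 1 to compound 3 (within the scatter) and no change at the digits printed from compound 2 to compound 3 (within the scatter), every one of them within the scatter and none lifting the value from the floor. A fourth aryl variant of the same kind is therefore expected to give no step beyond the scatter, and the expected step is a number 1 percentage points higher from compound 3 to compound 4 (within the scatter). For compound 4 the estimate in this assay is 1%, with a range from -8% to 12%.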

Compound 4, a percentage reported as inhibition, at one concentration (the size of the read-out at that concentration, not a potency): 0%
For compound 4 the middle estimate is 1 percentage points above the measured one; the range from low to high includes it.
By their numbers in this assay, from the lowest: compounds 2, 3, 4 and 1 (each within the scatter of the next).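

Among the compounds shown here, the new compound gives the first step in which only one substituent is added to the aryl group on the ring nitrogen, chloro in place of hydrogen on an aromatic carbon, and in this assay that step reads no change at the digits printed from compound 2 to compound 4 (within the scatter) at this single concentration. The exchanges of the whole aryl group read no change at the digits printed from compound 3 to compound 4 (within the scatter) and a number 1 percentage points lower from compound 1 to compound 4 (within the scatter) in the same assay, so chloro and trifluoromethyl together on one ring also leave the value at the floor. No measurement shown offers a reason for these values.

Every aryl group shown carries only chloro or trifluoromethyl, so it remains open whether a methoxy, a nitrile or a carboxylic acid on that ring would give a reading above the floor. Also open, on these data alone, is whether an amine or a longer chain in place of the aryl group would do so.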